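The compounds below may be only part of what the source reports. "The series", "measured", "known", "first", "only" and "open" are said of these compounds alone.

Measured in a functional assay on MCF7 cells (Homo sapiens) for inhibition, read by sulforhodamine B assay, with a stated time of 48 h, tested at 50 uM; on this read-out higher numbers stand for more inhibition of growth at the one concentration tested and lower numbers for less inhibition of growth:

- Compound 1 `CCCOc1ccc([C@@H]2CC(=O)c3cc(CC=C(C)C)c(OC)cc3O2)cc1` gives 60%
- Compound 2 `COc1ccc([C@@H]2C/C(=N/OCc3cn(-c4ccc(C#N)cc4)nn3)c3cc(CC=C(C)C)c(OC)cc3O2)cc1` gives 40%
- Compound 3 `COc1cc2c(cc1CC=C(C)C)C(=O)C[C@@H](c1ccc(Oc3ccc(F)cc3)cc1)O2` gives 37%

Compound 3 stands well under compound 1 and level, within the scatter, with compound 2. So it sits at the low end of this small set, though it is not clearly separated from compound 2.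

The next compound to consider is compound 4 `CCCCOc1ccc([C@@H]2CC(=O)c3cc(CC=C(C)C)c(OC)cc3O2)cc1`. The change from compound 3 is butyl in place of 4-fluorophenyl on an oxygen on an aromatic ring, which puts butyl in place of 4-fluorophenyl on an oxygen on an aromatic ring.

For the measured compounds named here, one measured step bears on this: a number 23 percentage points lower from compound 1 to compound 3 (beyond the scatter), where 4-fluorophenyl took the place of propyl at that oxygen. The new change runs almost the opposite way, returning to a plain chain, though butyl rather than propyl. Compound 2 differs from compound 3 in more than one place, so it gives no direct guide. Going by the values given here, no compound with butyl has been measured, so the effect of the longer chain remains open.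

Going by the size of the measured step from propyl to 4-fluorophenyl, the expected change is a number 19 percentage points higher from compound 3 to compound 4 (beyond the scatter), an upward move slightly smaller than that step reversed. In this assay the estimate for compound 4 is 56%, with an expected range from 41% to 71%.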

Compound 4, percent growth inhibition at one concentration: 57%
Compound 4: the middle estimate sits 1 percentage points below what was measured, and the stated range covers the measured number.
By their numbers in this assay, from the lowest: compounds 3 and 2 (each within the scatter of the next); then compounds 4 and 1 (each within the scatter of the next).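

In this assay the oxygen on the aromatic ring has now carried two plain chains and one ring, and the step of a number 20 percentage points higher from compound 3 to compound 4 (beyond the scatter) shows that the lower reading of 4-fluorophenyl is not shared by propyl alone, since butyl also stands clear of it. Lengthening propyl to butyl gives a number 3 percentage points lower from compound 1 to compound 4 (within the scatter), so the two chains cannot be told apart here, and at this oxygen the extra carbon brings no clear gain or loss in growth inhibition at the one concentration tested. The available data give no independent measurement that accounts for the gap between the chains and the 4-fluorophenyl ring.

The compounds shown leave open how far this tolerance for chains extends, for example to a longer hexyl chain or a branched isopropyl group. They also leave open whether an unsubstituted phenyl, or a ring held away from the oxygen by a carbon as in benzyl, would read with 4-fluorophenyl or with the plain chains.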